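This account rests on a few compounds, and the source may have more. Where it says the series, first, only, none or still open, it means among the compounds named here.

Measured so far:
- compound 1, `CCNC1=CC(=O)C=C(C(C)(C)C)C1=O`: 13000 nM
- compound 2, `CCCCCCCCNC1=CC(=O)C(C(C)(C)C)=CC1=O`: 70000 nM
- compound 3, `CCCCCCCCNC1=CC(=O)C=C(C[C@]2(C)[C@@H](C)CC[C@]3(C)C(C)=CCC[C@@H]23)C1=O`: 38000 nM

In a functional assay on NCI-H460 cells (Homo sapiens) for cytotoxicity, read by MTT assay, with a stated time of 72 h (a lower number here means a stronger inhibitor, a higher number a weaker inhibitor), compound 2 gives 70000 nM and stands at the highest number of the three. Compound 3 gives 38000 nM, which lies within the scatter of compound 2, so no order between these two can be read. Compound 1 gives 13000 nM, a number beyond the scatter below compound 2, and the only case in the set where a shorter chain on the amine nitrogen goes together with a lower number; compound 1 also carries a differently arranged core, so that pair is not a clean comparison.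

Compound 4, `CNC1=CC(=O)C(C(C)(C)C)=CC1=O`, keeps the core of compound 2 and shifts only the amine substituent: hydrogen in place of heptyl on a saturated chain carbon bound to an amine nitrogen. Within the data shown here, no measured pair isolates this change. The values of compound 1 and compound 2 give the only hint, and it points toward a lower number for compound 4, though the core differs between them. The step from compound 2 to compound 4 in this assay is expected to be small, toward a lower number, and possibly not beyond the scatter.

Compound 4 is estimated at 40000 nM, in the range 12000 nM to 120000 nM, an expected step of a 1.8-fold lower number from compound 2 to compound 4 (0.24 log units; within the scatter).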

Compound 4, half-maximal inhibitory concentration: 63000 nM
The estimate for compound 4 lay 1.6-fold (0.20 log units) below the measured number; the measured number falls inside the stated range.
By their numbers in this assay, from the lowest: compound 1; then compounds 3, 4 and 2 (each within the scatter of the next).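

In this assay, among these compounds, the pair of compound 2 and compound 4 gives the first clean reading at this place, on a saturated chain carbon bound to an amine nitrogen: a 1.1-fold lower number from compound 2 to compound 4 (0.05 log units; within the scatter) with hydrogen in place of heptyl on the shared core. Taking away the heptyl part, with its 7 carbon atoms, leaves no readable order between these two compounds, so the two chain lengths are not told apart by this assay on this core. The earlier gap involving compound 1 therefore cannot be assigned to the amine substituent, since the core of compound 1 is arranged differently, and nothing shown gives a reason for the result of this pair.

From the compounds shown here alone, only these two chain lengths are compared on this core, so it remains open whether a ring, a terminal amine or a carboxylic acid at the end of the chain would move the number beyond the scatter. Going by these compounds, it also remains open whether compound 1, at 13000 nM in this series, owes its place to its core or to its ethyl group, a question that an ethyl chain on the core of compound 2 would address.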